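A few compounds are considered here, and "the series" means these few. Any claim that something is new, unique, unknown or untested is made for them only; others in the source may bear on it.

Measured compounds and their values:
- Compound 1 `O=C(N/N=C/c1cccc(Cl)c1)c1cnccn1` gives 100% in an ADME assay on J774 cells (Mus musculus) for cytotoxicity, read by MTT assay, with a stated time of 48 h, tested at 150 ug/mL; on this read-out lower numbers stand for a stronger effect and higher numbers for a weaker effect at the one concentration tested.
- Compound 2 `CCOc1cccc(/C=N/NC(=O)c2cnccn2)c1` gives 69% in this assay.
- Compound 3 `N#Cc1cccc(/C=N/NC(=O)c2cnccn2)c1` gives 100% in this assay.

All three share one core and differ only in the group on the outer benzene ring. Compound 3 stands level with compound 1, the two together being the highest numbers of the three, which on this read-out means the weakest effect on the cells; the step of no change at the digits printed from compound 1 to compound 3 (within the scatter) confirms that swapping chloro for cyano did nothing that rises above the scatter. Compound 2 is the outlier: the step of a number 31 percentage points higher from compound 2 to compound 3 (beyond the scatter) is large, so the ethoxy compound is the only one with a clearly stronger effect.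

Compound 4 `O=C(N/N=C/c1cccc([N+](=O)[O-])c1)c1cnccn1` is the next member of the series. Its difference from compound 3 is nitro in place of cyano on an aromatic carbon.

Among the measured compounds shown here, no measured step exchanges a nitro group, so the guide is indirect. Two of the three groups tried at this position, chloro and cyano, gave the same number, and only ethoxy moved it. Nitro is closer in kind to those two small groups than to ethoxy, so the expected step of a number 2 percentage points lower from compound 3 to compound 4 (within the scatter) is none beyond the scatter. Compound 4 is therefore estimated at 98%, with a range from 84% to 106%.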

Compound 4, a percentage reported as activity, at one concentration (the size of the read-out at that concentration, not a potency): 76%
Estimate against measurement, compound 4: 22 percentage points above; the measured number lies below the stated range.
By their numbers in this assay, from the lowest: compounds 2 and 4 (each within the scatter of the next); then compounds 1 and 3 (each within the scatter of the next).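

In this assay, among the compounds shown here, ethoxy is no longer the only group on the outer benzene ring that moves the number, since the exchange of cyano for nitro gives a number 24 percentage points lower from compound 3 to compound 4 (beyond the scatter) and the exchange of chloro for nitro gives a number 24 percentage points lower from compound 1 to compound 4 (beyond the scatter) as well. So the earlier level pair of chloro and cyano did not mean that this position is indifferent to every group other than ethoxy. Nitro instead falls in with ethoxy, as the exchange of ethoxy for nitro gives only a number 7 percentage points higher from compound 2 to compound 4 (within the scatter) and the four compounds therefore form two sets in this assay, with chloro and cyano in one and ethoxy and nitro in the other.

An amine, a carboxylic acid or a chain longer than ethoxy at this same place could join either set or fall outside both, and the compounds shown give no way to tell which. Nothing measured here accounts for nitro and ethoxy falling together while chloro and cyano stay level.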